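Replacing the (1-phenylethyl)carbamoyl group of compound 3

The compounds below may be only part of what the source reports. "The series", "measured", "known", "first", "only" and "open" are said of these compounds alone.

Going by the values given here, in a functional assay on MCF7 cells (Homo sapiens) for antiproliferative activity, read by MTT assay, with a stated time of 24 h (on this read-out higher numbers stand for weaker inhibition and lower numbers for stronger inhibition), compound 3 `CCCCc1oc2ccccc2c1C(=O)c1ccc(OCC(=O)N[C@@H](C)c2ccccc2)cc1` gives 17900 nM, the lowest of the numbers measured so far. Compound 2 `CCCCc1oc2ccccc2c1C(=O)c1ccc(OCC(=O)Nc2cccc(OC)c2)cc1` gives 38500 nM. Compound 1 `CCCCc1oc2ccccc2c1C(=O)c1ccc(OCC(=O)NC(C)C)cc1` reads > 50000 nM, which is a limit of the assay and not a number.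

The next structure is compound 4 `CCCCc1oc2ccccc2c1C(=O)c1ccc(OCCCC(=O)N2CCCCC2)cc1`, and the change is 2-((piperidin-1-yl)carbonyl)ethyl in place of (1-phenylethyl)carbamoyl on a saturated chain carbon bound to an oxygen on an aromatic ring. The aromatic ring of the 1-phenylethyl group therefore leaves, and a six-membered non-aromatic ring enters.

The closest evidence comes from swaps on the amide nitrogen. The clearest is an at least 2.7-fold lower number from compound 1 to compound 3 (0.44 log units; beyond the scatter), where gaining 1-phenylethyl in place of isopropyl lowered the number. The step of a 2.2-fold lower number from compound 2 to compound 3 (0.33 log units; beyond the scatter) also favours compound 3. Aromatic groups alone do not make a rule, as compound 2 goes against one: an at least 1.2-fold lower number from compound 1 to compound 2 (0.11 log units; that floor lies within the scatter) stays within the scatter. Among the compounds with values here, compound 4 also differs in its chain, and no measured step covers that change.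

Giving up the 1-phenylethyl group should thus undo a modest gain, so a higher number and weaker inhibition are expected. The expected step is a 2.2-fold higher number from compound 3 to compound 4 (0.35 log units; beyond the scatter). Compound 4 is estimated at 40000 nM, within an expected range from 16000 nM to 90000 nM.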

Compound 4, half-maximal inhibitory concentration: 33000 nM
The estimate for compound 4 lay 1.2-fold (0.08 log units) above the measured number; the measured number falls inside the stated range.
By their numbers in this assay, from the lowest: compounds 3, 4 and 2 (each within the scatter of the next, the first and the last beyond it). At a limit, above all of these: compound 1.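

Swapping the (1-phenylethyl)carbamoyl group for the 2-((piperidin-1-yl)carbonyl)ethyl group in this assay gives a 1.8-fold higher number from compound 3 to compound 4 (0.27 log units; within the scatter), so at this position the aromatic ring, the defined stereocentre and the hydrogen-bond donor can all leave together without a change beyond the scatter. The comparison with the aromatic amide gives a 1.2-fold lower number from compound 2 to compound 4 (0.07 log units; within the scatter), which also stays within the scatter and shows that a six-membered non-aromatic ring with no hydrogen-bond donor can stand in the same range as these two aromatic amides. The step of an at least 1.5-fold lower number from compound 1 to compound 4 (0.18 log units; that floor lies within the scatter) gives only a floor because compound 1 stands at a limit of the assay and not at a number: the limit of > 50000 nM in this assay, at which 1 of the 4 values shown sits.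

Compound 4 changes the ring and the chain in one step, so the compounds shown cannot separate the effect of the piperidine ring from that of the longer chain, which a piperidin-1-yl amide on the chain of compound 3 would address. Going by these compounds, whether a morpholine ring, a primary amine or a free carboxylic acid could be carried at this position also remains open.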